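The source may hold more compounds than are shown below. What is called first, only, known or untested is meant among the compounds shown, and "the series" means these compounds.

Of the compounds shown here, three have so far been measured in a functional assay on A549 cells (Homo sapiens) for cytotoxicity, with a stated time of 48 h; a higher number here means a weaker inhibitor, a lower number a stronger inhibitor. Compound 1 `Cc1ccc2c(=O)cc(/C=C/[S+](C)[O-])oc2c1` gives 2000 nM. Compound 2 `CC(C)CC(=O)Oc1ccc2oc(/C=C/[S+](C)[O-])cc(=O)c2c1` gives 2300 nM. Compound 3 `C[S+]([O-])/C=C/c1oc2ccccc2c(=O)c1Cc1ccccc1` gives 1300 nM. Among these three, compound 2 gives the highest number, yet its gap to compound 1 and its gap to compound 3 each lie within the usual scatter of repeated measurements, so the three cannot be told apart, and none of them can be called the stronger or the weaker inhibitor.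

The next compound, compound 4 `CCCOc1ccc2oc(/C=C/[S+](C)[O-])cc(=O)c2c1`, differs from compound 2 in one place: propyl in place of isobutylcarbonyl on an oxygen on an aromatic ring. Seen one bond further out, (isobutylcarbonyl)oxy becomes propoxy. Among the compounds with values here, no pair of measured compounds differs in one place only, so there is no earlier step of this kind to lean on. Given that the three measured compounds, which carry quite different groups on the shared core, all land within the scatter of one another in this assay, the step from compound 2 to compound 4 is expected to be small, with no clear direction beyond the scatter, a 1.2-fold lower number from compound 2 to compound 4 (0.06 log units; within the scatter). Compound 4 is therefore estimated to give 2000 nM in this assay, with a range from 900 nM to 4500 nM.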

Compound 4, half-maximal inhibitory concentration: 1100 nM
Beside the measured number, compound 4's estimate is 1.8-fold (0.26 log units) above it; low and high end bracket the measured number.
By their numbers in this assay, from the lowest: compounds 4, 3, 1 and 2 (each within the scatter of the next, the first and the last beyond it).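

Replacing isobutylcarbonyl with propyl on this oxygen on an aromatic ring gives a 2.1-fold lower number from compound 2 to compound 4 (0.32 log units; beyond the scatter) in this assay, so the group here can shift the number by a modest amount, just past the usual scatter. The earlier compounds shown here could not show this, as no two of them differed in one place only, and none of their gaps went beyond the scatter. The step changes several things at once: the leaving group is larger and carries a double bond and a hydrogen-bond acceptor, while propyl has neither, and no measurement offers an explanation for the difference.

A single step cannot separate the loss of the carbonyl from the shortening of the chain, which an isobutyl group or a propanoyl group on the same oxygen would help to pull apart. Also open, on these data alone, is whether the trend continues with a longer chain such as hexyl, or how a free hydroxyl or an amine-bearing chain would behave at this position.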